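The source may hold more compounds than are shown below. What is called first, only, known or untested is meant among the compounds shown, and "the series" means these compounds.

Measured compounds:
- compound 1, `C[C@@H](NC(=O)c1ccc(C#Cc2cccc(F)c2)cn1)C(C)(C)C`, in an ADME assay on HEK293 cells for agonist activity at metabotropic glutamate receptor 5 (Rattus norvegicus), read by fluorescence and calcium flux (on this read-out lower numbers stand for smaller maximal responses and higher numbers for larger maximal responses), compound 1 gives 31.2%
- compound 2, `C[C@H](NC(=O)c1ccc(C#Cc2cccc(F)c2)cn1)C(C)(C)C`, compound 2 gives 20%
- compound 3, `CC(C)(C)CNC(=O)c1ccc(C#Cc2cccc(F)c2)cn1`, compound 3 gives 9.5%

Compound 3 stands lowest of the three numbers in this assay. Its nearest neighbour is compound 2, and the step of a number 10.5 percentage points lower from compound 2 to compound 3 (beyond the scatter) lies beyond the scatter; the step of a number 21.7 percentage points lower from compound 1 to compound 3 (beyond the scatter) is larger still. Within the pair of neopentyl-bearing compounds, the step of a number 11.2 percentage points lower from compound 1 to compound 2 (beyond the scatter) rests on (the fact that compounds 1 and 2 differ only in the configuration as drawn).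

The next compound is compound 4, `O=C(NCC1CCC1)c1ccc(C#Cc2cccc(F)c2)cn1`. It differs from compound 3 in one place: cyclobutyl in place of tert-butyl on a saturated chain carbon bound to an amide-type nitrogen. Within the data shown here, none of the measured steps concerns this exchange: the steps already seen turn on a methyl against hydrogen at the saturated chain carbon and on configuration, not on the group carried by that carbon. They show only that removing the methyl lowered the response by a modest amount in both cases. Among the measured compounds shown here, with no step bearing directly on a cyclobutyl for tert-butyl exchange, and compound 3 already near the bottom of the range seen, no step beyond the scatter is expected in either direction. The estimate for compound 4 is therefore 11%, with a range from 3% to 24%, meaning an expected step of a number 1.5 percentage points higher from compound 3 to compound 4 (within the scatter).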

Compound 4, largest response reached (reported as efficacy), in percent of the reference or control that the assay uses: 4.7%
Beside the measured number, compound 4's estimate is 6.3 percentage points above it, and the stated range covers the measured number.
By their numbers in this assay, from the lowest: compounds 4 and 3 (each within the scatter of the next); then compound 2; then compound 1.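

In this assay, among these compounds, the first change to the group carried by the saturated chain carbon bound to an amide-type nitrogen, cyclobutyl in place of tert-butyl, gives a number 4.8 percentage points lower from compound 3 to compound 4 (within the scatter), so a four-membered ring of carbon and an open tert-butyl with the same count of heavy atoms are not separated at this position on this read-out. The steps that span two differences, a number 15.3 percentage points lower from compound 2 to compound 4 (beyond the scatter) and a number 26.5 percentage points lower from compound 1 to compound 4 (beyond the scatter), place compound 4 with compound 3 in the group without a methyl on the chain carbon next to the nitrogen as drawn in compounds 1 and 2, so among these four compounds only the two methyl-bearing compounds stand clear of the low end. No measured evidence on hand bears on why the cyclobutyl exchange behaves this way.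

Still open, as far as these compounds go, is whether a methyl on the chain carbon of the cyclobutylmethyl amide would raise the response as it does with the neopentyl amide, and whether the drawn configuration would matter there. Also open, from the compounds shown here alone, is how a cyclopentyl ring, a phenyl ring or an amine carried on that carbon would compare with tert-butyl and cyclobutyl.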